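The source may hold more compounds than are shown below. What is called first, only, known or untested is meant among the compounds shown, and "the series" means these compounds.

Compound 1, `CC(C)NC(=O)CC(c1ccc(-c2ccc3cccc(F)c3c2)[nH]c1=O)C(C)C`, in an ADME assay on microsomes from liver (Rattus norvegicus) for metabolic stability (a higher number here means that the compound lasts longer, a lower number that the compound disappears faster), gives < 0.0667 h, which is a limit of the assay (the limit of < 0.0667 h in this assay, at which 1 of the 3 values shown sits). Compound 2, `CCn1ncc2c(F)cc(-c3ccc(C(CC)(CC)c4ncn(C)n4)c(=O)[nH]3)cc21`, in this assay gives > 3 h, again a limit of the assay (the limit of > 3 h in this assay, at which 1 of the 3 values shown sits). Compound 3, `CC(C)C(c1ccc(-c2ccc3cccc(F)c3c2)[nH]c1=O)N1CCNC1=O`, in this assay gives 0.283 h.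

Compound 3 therefore carries the only half-life reported as a number; the other two results are limits. The compound to be measured is compound 4, `CC(C)C(CC(N)=O)c1ccc(-c2ccc3cccc(F)c3c2)[nH]c1=O`. Its difference from compound 3 is carbamoylmethyl in place of 2-oxoimidazolidin-1-yl on a saturated chain carbon bound to an aromatic carbon and a saturated chain carbon. Among the compounds with values here, the one measured step that bears on this position is an at least 4.2-fold higher number from compound 1 to compound 3 (0.62 log units; beyond the scatter), in which the ring replaced an acyclic amide chain at this same saturated chain carbon. Compound 4 returns to an acyclic amide chain there, a shorter one than in compound 1, so the step is expected to run the other way: a modest to at least modest drop, a 2.8-fold lower number from compound 3 to compound 4 (0.45 log units; beyond the scatter). Compound 4 is expected to give about 0.1 h in this assay, within 0.04 h to 0.3 h, with a fair chance that only a limit is reported.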

Compound 4, half-life: < 0.0667 h
Compound 4 ended at the assay's limit; the forecaster's own chance of this, stated with the estimate: 30%; at least 1.4-fold (0.17 log units) between middle value and limit.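

Putting carbamoylmethyl in place of 2-oxoimidazolidin-1-yl on this saturated chain carbon gives an at least 4.2-fold lower number from compound 3 to compound 4 (0.62 log units; beyond the scatter). In this assay compound 4 gives < 0.0667 h, which is a limit of the assay: the limit of < 0.0667 h in this assay, at which 2 of the 4 values shown sit. Both compounds with an open amide chain at this carbon therefore fall short of compound 3, whether or not the amide-type nitrogen carries isopropyl, while the step between compound 1 and compound 4 cannot be read from two limits.

Going by these compounds, how much shorter the half-lives of compound 1 and compound 4 are than that limit stays open, and so does any effect of the isopropyl. Also open, on these data alone, is whether an open chain ending in an amine or a carboxylic acid at this carbon would match 2-oxoimidazolidin-1-yl.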